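Ketone to Alcohol Swap Repeated on a Second Core

A few compounds are considered here, and "the series" means these few. Any claim that something is new, unique, unknown or untested is made for them only; others in the source may bear on it.

Compound 1 `CCN(CC)CCNC(=O)c1ccc(C(CC)(CC)c2ccc(OCC(=O)C(C)(C)C)c(C)c2)n1CC` was tested in a functional assay on Caco-2 cells (Homo sapiens), read by MTT assay, with a stated time of 48 h (on this read-out lower numbers stand for stronger inhibition and higher numbers for weaker inhibition), where compound 1 gives 1600 nM. Compound 2 `CCN(CC)CCNC(=O)c1ccc(C(CC)(CC)c2ccc(OCC(O)C(C)(C)C)c(C)c2)n1CC` carries a single change from it, (1-hydroxy-2,2-dimethylpropyl in place of (tert-butyl)carbonyl on a saturated chain carbon bound to an oxygen on an aromatic ring), and in this assay compound 2 gives 2310 nM; the step is a 1.4-fold higher number from compound 1 to compound 2 (0.16 log units; within the scatter). Compound 3 `CC[C@@H](C)[C@H](NC(=O)c1ccc(C(CC)(CC)c2ccc(OCC(=O)C(C)(C)C)c(C)c2)n1CC)C(=O)O` differs from compound 1 in its core, (1-carboxy-2-methylbutyl in place of 2-(diethylamino)ethyl on an amide-type nitrogen), and in this assay compound 3 gives 4500 nM, a step of a 2.8-fold higher number from compound 1 to compound 3 (0.45 log units; beyond the scatter). Compound 4 `CC[C@@H](C)[C@H](NC(=O)c1ccc(C(CC)(CC)c2ccc(OCC(O)C(C)(C)C)c(C)c2)n1CC)C(=O)O` has not yet been measured; it stands to compound 3 as compound 2 stands to compound 1, the same change at the same place, (1-hydroxy-2,2-dimethylpropyl in place of (tert-butyl)carbonyl on a saturated chain carbon bound to an oxygen on an aromatic ring). Because a 1.4-fold higher number from compound 1 to compound 2 (0.16 log units; within the scatter) stayed within the scatter, the step from compound 3 to compound 4 is expected to be of similar size, a 1.4-fold higher number from compound 3 to compound 4 (0.15 log units; within the scatter). Compound 4 is accordingly estimated at 6300 nM, with a range from 3000 nM to 13000 nM.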

Compound 4, half-maximal inhibitory concentration: 3400 nM
For compound 4 the middle estimate is 1.9-fold (0.27 log units) above the measured one; the range from low to high includes it.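

In this assay, putting 1-hydroxy-2,2-dimethylpropyl in place of (tert-butyl)carbonyl on the second core gives a 1.3-fold lower number from compound 3 to compound 4 (0.12 log units; within the scatter), and this step agrees with the earlier one on the core of compound 1: the same change on two cores in this assay, a 1.4-fold higher number (0.16 log units; within the scatter) from compound 1 to compound 2 and a 1.3-fold lower number (0.12 log units; within the scatter) from compound 3 to compound 4, 1.9-fold (0.28 log units) apart, within the scatter of two such steps. Putting 1-carboxy-2-methylbutyl in place of 2-(diethylamino)ethyl on the amide-type nitrogen of the alcohol gives a 1.5-fold higher number from compound 2 to compound 4 (0.17 log units; within the scatter), and this step also agrees with its earlier counterpart: the same change on two cores in this assay, a 2.8-fold higher number (0.45 log units; beyond the scatter) from compound 1 to compound 3 and a 1.5-fold higher number (0.17 log units; within the scatter) from compound 2 to compound 4, 1.9-fold (0.28 log units) apart, within the scatter of two such steps. The ketone-to-alcohol change thus carries between these two cores without a step beyond the scatter, yet both of its steps lie within the scatter, so no real effect or direction of the change is shown, and two cores set no rule for the series.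

The compounds shown leave open whether an amine or a methyl ether in place of the hydroxy group would give a step beyond the scatter. They also leave open whether the change would carry to a core with a primary amide in place of the carboxylic acid.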